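A few compounds are considered here, and "the series" means these few. Any claim that something is new, unique, unknown or untested is made for them only; others in the source may bear on it.

Measured compounds:
- compound 1, `CC(C)(C)c1ccc(OCCCCCn2ccc(=O)[nH]c2=O)cc1`: 100000 nM in an ADME assay on HEL cells (Homo sapiens) for cytotoxicity, read by microscopy; on this read-out higher numbers stand for lower toxicity in this test and lower numbers for higher toxicity in this test
- compound 2, `O=c1ccn(CCCOc2ccc(Br)cc2)c(=O)[nH]1`: in this assay compound 2 gives > 100000 nM, a limit of the assay and not a number.

Among the compounds with values here, compound 1 carries the only numeric value shown in this assay; the other result is a limit, (the limit of > 100000 nM in this assay, at which 1 of the 2 values shown sits). Within the data shown here, no step between measured compounds is available, so the change from compound 1 to compound 3 is not anchored by any measured pair.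

Compound 3, `O=c1ccn(CCCCCOc2ccc(-c3ccccc3)cc2)c(=O)[nH]1`, differs from compound 1 by phenyl in place of tert-butyl on an aromatic carbon. Among the measured compounds shown here, with no measured step to lean on, the expectation for this assay is a step of no size beyond the scatter, in either direction: compound 3 is expected to sit close to compound 1, the estimated step being no change at the digits printed from compound 1 to compound 3 (within the scatter). The estimate for compound 3 in this assay is 100000 nM, with a range from 50000 nM to 200000 nM, and a fair chance that only a limit is reported.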

Compound 3, minimum cytotoxic concentration: 100000 nM
Estimate against measurement, compound 3: no gap at the digits printed; low and high end bracket the measured number.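

With phenyl in place of tert-butyl on an aromatic carbon, para to a large group, this assay gives no change at the digits printed from compound 1 to compound 3 (within the scatter). Within the data shown here, this is the first single change that can be read, and it shows that this position accepts a six-membered aromatic ring of carbon only in place of tert-butyl without a change beyond the scatter in this read-out. Compound 2 gives a limit of the assay and not a number: the limit of > 100000 nM in this assay, at which 1 of the 3 values shown sits.

Among these compounds, compound 2 differs from compound 1 in more than one place, so no step to it can be read. On these data alone, whether an amine or a carboxylic acid at this position, or a longer chain on the shared core, would shift the reading in this assay remains open.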